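Adding a Methyl Branch: Cytotoxicity Limits in Macrophages

The source may hold more compounds than are shown below. What is called first, only, known or untested is meant among the compounds shown, and "the series" means these compounds.

Compound 1 `O=C(CN1C(=O)CSC1=O)NOCc1ccccc1`: > 128000 nM
Compound 2 `CC(C(=O)NOCc1ccccc1)N1C(=O)CSC1=O`: > 128000 nM
Compound 3 `O=C(CN1C(=O)S/C(=C\c2ccccc2)C1=O)NOCc1ccccc1`: > 128000 nM

Each of these three values is a limit of the assay, not a number. In an ADME assay on RAW264.7 cells (Mus musculus) for cytotoxicity, read by neutral red uptake, with a stated time of 24 h (on this read-out higher numbers stand for lower toxicity in this test and lower numbers for higher toxicity in this test), compound 1 gives > 128000 nM as a limit. Compound 2 gives > 128000 nM as a limit. Compound 3 gives > 128000 nM as a limit. The change from compound 1 to compound 2 is methyl in place of hydrogen on a saturated chain carbon bound to an amide-type nitrogen in a ring and a carbonyl carbon, and its step that the two limits leave unreadable from compound 1 to compound 2 stays unreadable because of the limit of > 128000 nM in this assay, at which 3 of the 3 values shown sit. The difference between the core of compound 1 and the core of compound 3 is not broken down here. Compound 4 `CC(C(=O)NOCc1ccccc1)N1C(=O)S/C(=C\c2ccccc2)C1=O` differs from compound 3 by methyl in place of hydrogen on a saturated chain carbon bound to an amide-type nitrogen in a ring and a carbonyl carbon, the same change at the same place. In this assay compound 4 is expected to show a step that the limit leaves unreadable from compound 3 to compound 4, resting on compound 3 sitting at > 128000 nM. Compound 4 is therefore estimated at 200000 nM.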

Compound 4, half-maximal cytotoxic concentration: > 128000 nM
Compound 4: only a limit was reported; the forecaster's own chance of this, stated with the estimate: 85%; the middle value lies beyond the limit too.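

Within the data shown here, compound 3 and compound 4 both give a limit rather than a number, so no step between them can be read: the limit of > 128000 nM in this assay, at which 4 of the 4 values shown sit. Still open is what concentration of any of these compounds, if any, would prove toxic in this assay.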